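Methylsulfanyl for chloro on the benzyl arm

This account rests on a few compounds, and the source may have more. Where it says the series, first, only, none or still open, it means among the compounds named here.

Compound 3 `O=c1c2ccccc2c(Cc2ccc(Cl)cc2)nn1-c1ccc(Br)cc1` shows only a limit in a functional assay on aorta with Alpha-1D adrenergic receptor (Rattus norvegicus) as the target; on this read-out higher numbers stand for an effect only at larger amounts of compound and lower numbers for an effect already at smaller amounts: compound 3 gives > 30000 nM, a limit of the assay and not a number. Compound 1 `CCCCn1nc(Cc2ccc(SC)cc2)c2ccccc2c1=O` gives > 100000 nM in this assay, likewise a limit. Compound 2 `C=CCn1nc(Cc2ccc(SC)cc2)c2ccccc2c1=O` gives > 100000 nM, also a limit. Among the compounds with values here, the step that the two limits leave unreadable from compound 1 to compound 2 is therefore unreadable, and no measured step bears on the present change. Compound 4 `CSc1ccc(Cc2nn(-c3ccc(Br)cc3)c(=O)c3ccccc23)cc1` differs from compound 3 by methylsulfanyl in place of chloro on an aromatic carbon. Compounds 1 and 2 already carry the methylsulfanyl group and sit at the limit of > 100000 nM in this assay, at which 2 of the 3 values shown sit. Compound 3 sits at the limit of > 30000 nM in this assay, at which 1 of the 3 values shown sits. No effect beyond the scatter is expected, and compound 4 is expected to return a limit again. The expected step that the limit leaves unreadable from compound 3 to compound 4 is nominal only. Compound 4 is estimated at 100000 nM, within 30000 nM to 300000 nM.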

Compound 4, half-maximal effective concentration: > 100000 nM
Compound 4: no number, only a limit; the forecaster's own chance of this, stated with the estimate: 85%; the middle value sits exactly at the limit.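

Within the data shown here, compound 1, compound 2, compound 3 and compound 4 all show only limits and no numbers, and no step among them can be read. The compounds shown leave open whether any substitution on this core gives a measurable effect in this assay.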